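From compound 1 to compound 4: a side-chain exchange

This account rests on a few compounds, and the source may have more. Where it says the series, first, only, none or still open, it means among the compounds named here.

In a functional assay on OVCAR-8 cells (Homo sapiens) for antiproliferative activity (a higher number here means a weaker inhibitor, a lower number a stronger inhibitor), three compounds have been measured.
- Compound 1 (`Cn1ncc(Cl)c1-c1cc(C(=O)N[C@@H]2CN[C@H](CCN3CCC(O)CC3)C[C@H]2c2ccc(Cl)c(Cl)c2)oc1Cl`) gives 15900 nM
- Compound 2 (`Cn1ncc(Cl)c1-c1cc(C(=O)N[C@@H]2CNCC[C@H]2c2ccc(C(F)(F)F)cc2)oc1Cl`) gives 120 nM
- Compound 3 (`C=CC[C@@H]1C[C@@H](c2ccc(Cl)c(Cl)c2)[C@H](NC(=O)c2cc(-c3c(Cl)cnn3C)c(Cl)o2)CN1`) gives 990 nM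

Compound 1 has the highest number of the three, and compound 3 and compound 2 both lie beyond the scatter below it. For the measured compounds named here, compound 4 (`Cn1ncc(Cl)c1-c1cc(C(=O)N[C@@H]2CN[C@H](CC(=O)NCC(O)CO)C[C@H]2c2ccc(Cl)c(Cl)c2)oc1Cl`) differs from compound 1 by (2,3-dihydroxypropyl)carbamoyl in place of (4-hydroxypiperidin-1-yl)methyl on a saturated chain carbon bound to a saturated ring carbon as its single change. Going by the values given here, the one measured step that also removes (4-hydroxypiperidin-1-yl)methyl at that place is a 16-fold lower number from compound 1 to compound 3 (1.21 log units; beyond the scatter) and it is large. Compound 2 differs from compound 1 in more than one place. Among the compounds with values here, no measured compound carries (2,3-dihydroxypropyl)carbamoyl, so a smaller step in the same direction is expected. The expected step is a 4.0-fold lower number from compound 1 to compound 4 (0.60 log units; beyond the scatter) in this assay by this estimate. For compound 4 the estimated value is 4000 nM with an expected range from 1200 nM to 15000 nM in this assay.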

Compound 4, half-maximal inhibitory concentration: 5900 nM
For compound 4 the middle estimate is 1.5-fold (0.17 log units) below the measured one, and the stated range covers the measured number.
By their numbers in this assay, from the lowest: compound 2; then compound 3; then compound 4; then compound 1.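

In this assay, (2,3-dihydroxypropyl)carbamoyl at this place on a saturated chain carbon gives only a partial gain, with a 2.7-fold lower number from compound 1 to compound 4 (0.43 log units; beyond the scatter), whereas replacing vinyl with the same group gives a 6.0-fold higher number from compound 3 to compound 4 (0.78 log units; beyond the scatter). The side chain therefore sets a graded order among these three compounds, and a group with no ring and the same count of heavy atoms as (4-hydroxypiperidin-1-yl)methyl does not match vinyl. Nothing available explains this order.

Going by these compounds, it remains open whether a carboxylic acid or a primary amine at this place would fall nearer compound 3 or compound 1. On these data alone, an unsubstituted propyl chain also remains untested here as a comparison with vinyl.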